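Working notes: cytotoxicity across four cyclic amine carboxamides

A few compounds are considered here, and "the series" means these few. Any claim that something is new, unique, unknown or untested is made for them only; others in the source may bear on it.

Compound 1 `Cc1cc(C)cc(S(=O)(=O)c2c(C(=O)N[C@@H]3CCN(Cc4ccccc4F)C3)[nH]c3ccc(Cl)cc23)c1`, compound 2 `Cc1cc(C)cc(S(=O)(=O)c2c(C(=O)N[C@@H]3CCN(S(C)(=O)=O)C3)[nH]c3ccc(Cl)cc23)c1`, compound 3 `Cc1cc(C)cc(S(=O)(=O)c2c(C(=O)NC3CN(S(C)(=O)=O)C3)[nH]c3ccc(Cl)cc23)c1` and the unmeasured compound 4 `Cc1cc(C)cc(S(=O)(=O)c2c(C(=O)NC3CN(Cc4ccccc4F)C3)[nH]c3ccc(Cl)cc23)c1` share one core. In an ADME assay on MT4 cells (Homo sapiens) for cytotoxicity, read by MTT assay, with a stated time of 5 days (on this read-out higher numbers stand for lower toxicity in this test and lower numbers for higher toxicity in this test), compound 2 gives 24000 nM. Compound 1 reaches only a limit in this assay, > 231000 nM. Compound 3 likewise reaches only a limit, > 252000 nM. The change 2-fluorobenzyl in place of methylsulfonyl on an amine nitrogen in a ring produces an at least 9.6-fold higher number from compound 2 to compound 1 (0.98 log units; beyond the scatter), the value sitting at the limit of > 231000 nM in this assay, at which 1 of the 3 values shown sits. The two cores differ by 1-(methylsulfonyl)azetidin-3-yl in place of 1-(methylsulfonyl)pyrrolidin-3-yl on an amide-type nitrogen, which produces an at least 10-fold higher number from compound 2 to compound 3 (1.02 log units; beyond the scatter), the value sitting at the limit of > 252000 nM in this assay, at which 1 of the 3 values shown sits. Compound 4 carries the same kind of change, (2-fluorobenzyl in place of methylsulfonyl on an amine nitrogen in a ring), here on a four-membered rather than a five-membered ring. For compound 4 the expected step of a number no higher from compound 3 to compound 4 (the limit leaves the size open) is small, because compound 3 already sits at the limit of > 252000 nM in this assay, at which 1 of the 3 values shown sits, and compound 1 at the limit of > 231000 nM in this assay, at which 1 of the 3 values shown sits. Compound 4 is estimated at 250000 nM, most likely again reported as a limit, expected between 60000 nM and 600000 nM.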

Compound 4, half-maximal cytotoxic concentration: > 238000 nM
Compound 4 was reported as a limit (the forecaster's own chance of this, stated with the estimate: 75%); the middle value is on the limit's open side.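

In this assay compound 4 gives > 238000 nM, which is a limit of the assay and not a number. Replacing methylsulfonyl with 2-fluorobenzyl gives an at least 9.6-fold higher number from compound 2 to compound 1 (0.98 log units; beyond the scatter), but the corresponding step on the four-membered ring cannot be read, so the data neither show nor exclude that the change carries over from one core to the other. Among the compounds shown here, the one readable new step is an at least 9.9-fold higher number from compound 2 to compound 4 (0.99 log units; beyond the scatter), with 1-(2-fluorobenzyl)azetidin-3-yl in place of 1-(methylsulfonyl)pyrrolidin-3-yl, and it does not isolate the 2-fluorobenzyl change. The compounds shown leave open whether an acetyl group or a longer chain such as 2-phenylethyl on the ring nitrogen of the four-membered ring would give a number rather than a limit in this assay.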